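Sulfonyl aryl substitution in a cytotoxicity series

A few compounds are considered here, and "the series" means these few. Any claim that something is new, unique, unknown or untested is made for them only; others in the source may bear on it.

Measured compounds:
compound 1 `CCCc1nc2c(C)cc(-c3nc4ccccc4n3C)cc2n1S(=O)(=O)c1ccccc1` — > 50000 nM
compound 2 `CCCc1nc2c(C)cc(-c3nc4ccccc4n3C)cc2n1S(=O)(=O)c1ccc(C)cc1` — > 50000 nM

All values come from a functional assay on A549 cells (Homo sapiens) for cytotoxicity, read by MTT assay; a higher number here means a weaker inhibitor, a lower number a stronger inhibitor. For compound 1 the value > 50000 nM is a limit of the assay and not a number. For compound 2 the value > 50000 nM is likewise a limit. Within the data shown here, compound 1 therefore stands only at a limit, and the one further value shown is also a limit. Among the measured compounds shown here, the single measured step, a step that the two limits leave unreadable from compound 1 to compound 2, methyl in place of hydrogen on an aromatic carbon, cannot be sized because both values sit at the limit of > 50000 nM in this assay, at which 2 of the 2 values shown sit.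

Compound 3 `CCCc1nc2c(C)cc(-c3nc4ccccc4n3C)cc2n1S(=O)(=O)c1c(C)cc(C)cc1C` is not yet measured in this assay. Its change from compound 1 is 2,4,6-trimethylphenyl in place of phenyl on a sulfonyl sulfur. For the measured compounds named here, the only step that bears on it is the one from compound 1 to compound 2, which also adds methyl to the ring on the sulfonyl sulfur and is unreadable, so no step beyond the scatter can be derived in either direction; a limit is again expected. Compound 3 is expected at 80000 nM, within 30000 nM to 300000 nM. The expected step is a step that the limit leaves unreadable from compound 1 to compound 3.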

Compound 3, half-maximal inhibitory concentration: > 50000 nM
Compound 3 gave a limit, no number; the forecaster's own chance of this, stated with the estimate: 85%; the middle value is on the limit's open side.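

No step among compound 1, compound 2 and compound 3 can be read, because all three values are limits of the assay and not numbers: the limit of > 50000 nM in this assay, at which 3 of the 3 values shown sit.

The compounds shown leave open whether any group on the sulfonyl sulfur of the shared core would give a readable value, and so whether phenyl, 4-methylphenyl and 2,4,6-trimethylphenyl differ at all.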